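A few compounds are considered here, and "the series" means these few. Any claim that something is new, unique, unknown or untested is made for them only; others in the source may bear on it.

Measured in an assay on CHO cells for displacement of a labelled ligand from adenosine receptor A3 (Homo sapiens), read by scintillation counting, with a stated time of 120 min; a higher number here means a weaker inhibitor, a lower number a stronger inhibitor:
Compound 1 `COc1cccc(CNc2nc(N)c3nc(-c4ccc(C)o4)sc3n2)c1` gives 160 nM.
Compound 2 `Cc1ccc(-c2nc3c(N)nc(NCc4cccs4)nc3s2)o1` gives 15.3 nM.
Compound 3 `Nc1nc(NCc2ccco2)nc2sc(-c3ccco3)nc12` gives 4.72 nM.

Compound 3 stands lowest of the three in this assay; compound 2 is nearest to it and compound 1 furthest. Compound 4 `Nc1nc(NCc2ccsc2)nc2sc(-c3ccco3)nc12` differs from compound 3 in one place: thiophen-3-yl in place of furan-2-yl on a saturated chain carbon bound to a nitrogen on an aromatic ring. For the measured compounds named here, the only measured step at this place is a 10-fold lower number from compound 1 to compound 2 (1.02 log units; beyond the scatter), where a six-membered ring gave way to a five-membered one. The present change exchanges one five-membered ring for another of the same size, so a smaller shift is expected. Compound 2 with a thiophen-2-yl at this place shows 15.3 nM, but it differs from compound 3 in more than one place. The expected step is a 1.4-fold higher number from compound 3 to compound 4 (0.14 log units; within the scatter), within the scatter. Compound 4 is estimated at 6.5 nM, between 2.5 nM and 17 nM.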

Compound 4, inhibition constant: 3.14 nM
The estimate for compound 4 lay 2.1-fold (0.32 log units) above the measured number, within the range that was stated.
By their numbers in this assay, from the lowest: compounds 4 and 3 (each within the scatter of the next); then compound 2; then compound 1.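

In this assay, thiophen-3-yl in place of furan-2-yl gives a 1.5-fold lower number from compound 3 to compound 4 (0.18 log units; within the scatter), so the two compounds cannot be told apart. At this place on the saturated chain carbon, then, one five-membered aromatic ring with a sulfur can stand in for another with an oxygen, even though the earlier step showed that the group here can matter greatly. Nothing available explains this result.

Open, on these data alone, is whether a cyclohexyl ring, with no aromatic ring at all, would keep the number this low. So is whether a longer chain ending in an amine would.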